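The source may hold more compounds than are shown below. What is called first, only, known or untested is meant among the compounds shown, and "the series" means these compounds.

Measured in a functional assay on HEp-2 cells (Homo sapiens) for antiproliferative activity, read by MTT assay, with a stated time of 72 h; a lower number here means a stronger inhibitor, a higher number a weaker inhibitor: compound 1 `O=c1cc(CSC(=S)N2CCCCC2)oc2cc(Cl)ccc12` gives 1600 nM; compound 2 `O=c1c(Cl)c(CSC(=S)N2CCCCC2)oc2ccccc12` gives 940 nM; compound 3 `CC(C)N(C(=S)SCc1cc(=O)c2ccc(Cl)cc2o1)C(C)C` gives 22700 nM.

Compound 3 stands highest of the three numbers in this assay, compound 1 being nearest to it and compound 2 furthest, both gaps beyond the scatter. Among the measured compounds shown here, the one single-point step recorded, a 14-fold higher number from compound 1 to compound 3 (1.15 log units; beyond the scatter), is what sets compound 3 apart: exchanging a six-membered ring amine for an open-chain dialkylamine on the thiocarbonyl carbon raised the number sharply.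

Compound 4 `O=c1cc(CSC(=S)N2CCOCC2)oc2cc(Cl)ccc12` differs from compound 3 by morpholin-4-yl in place of diisopropylamino on a thiocarbonyl carbon. This largely reverses that step: a six-membered non-aromatic ring amine returns to the thiocarbonyl carbon, as in compound 1. For the measured compounds named here, no measured pair compares morpholin-4-yl with piperidin-1-yl directly, so whether the ring oxygen shifts the number is not known from these data. The expectation is therefore a step back toward compound 1, large and downward, in this assay.

Compound 4 is expected at 2500 nM (range 900 nM to 8000 nM), an estimated step of a 9.1-fold lower number from compound 3 to compound 4 (0.96 log units; beyond the scatter).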

Compound 4, half-maximal inhibitory concentration: 20600 nM
Estimate against measurement, compound 4: 8.2-fold (0.92 log units) below; measured number outside the range, above it.
By their numbers in this assay, from the lowest: compounds 2 and 1 (each within the scatter of the next); then compounds 4 and 3 (each within the scatter of the next).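

In this assay, a six-membered non-aromatic ring amine on the thiocarbonyl carbon does not by itself keep the number low: morpholin-4-yl in place of diisopropylamino makes no change beyond the scatter (a 1.1-fold lower number from compound 3 to compound 4 (0.04 log units; within the scatter)). The low number of compound 1 is instead tied, among these compounds, to piperidin-1-yl, since morpholin-4-yl in its place gives a large rise (a 13-fold higher number from compound 1 to compound 4 (1.11 log units; beyond the scatter)). Nothing measured here explains this difference between the two ring amines.

From the compounds shown here alone, it remains open whether other amines on the thiocarbonyl carbon, such as pyrrolidin-1-yl, 4-methylpiperazin-1-yl or open-chain diethylamino, would fall with compound 1 or with compounds 3 and 4. Also open, going by these compounds, is whether morpholin-4-yl would cost as much on the core of compound 2.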